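The source may report more compounds than this note shows. Statements on the series, on what has been measured and on what is new or still open speak of the compounds shown alone.

Within the data shown here, compound 2 `COc1cc2c(cc1CC=C(C)C)C(=O)C[C@@H](c1ccc(Oc3ccc(F)cc3)cc1)O2` stands lowest of the three measured members in a functional assay on A549 cells (Homo sapiens) for inhibition, read by sulforhodamine B assay, with a stated time of 48 h, tested at 50 uM (on this read-out lower numbers stand for less inhibition of growth and higher numbers for more inhibition of growth at the one concentration tested), where compound 2 gives 27%. Compound 1 `COc1ccc([C@@H]2C/C(=N/OCc3cn(-c4ccccc4CO)nn3)c3cc(CC=C(C)C)c(OC)cc3O2)cc1` gives 100% and compound 3 `COc1ccc([C@@H]2C/C(=N/OCc3cn(-c4cccc(CO)c4)nn3)c3cc(CC=C(C)C)c(OC)cc3O2)cc1` gives 43%. Among the measured compounds shown here, the one measured step, a number 57 percentage points lower from compound 1 to compound 3 (beyond the scatter), concerns the substituent on the aromatic nitrogen and does not touch the place changed here. Compound 4 `COc1ccc([C@@H]2CC(=O)c3cc(CC=C(C)C)c(OC)cc3O2)cc1` differs from compound 2 by methyl in place of 4-fluorophenyl on an oxygen on an aromatic ring. For the measured compounds named here, no measured step bears on this change, and compounds 1 and 3 differ from compound 2 in more than one place. The step of a number 7 percentage points lower from compound 2 to compound 4 (within the scatter) is therefore expected to be small, within the scatter or slightly downward. Compound 4 is estimated at 20%, with a range of 5% to 45%.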

Compound 4, percent growth inhibition at one concentration: 45%
For compound 4 the middle estimate is 25 percentage points below the measured one; the range from low to high includes it.
By their numbers in this assay, from the lowest: compound 2; then compounds 3 and 4 (each within the scatter of the next); then compound 1.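

In this assay the change from 4-fluorophenoxy to methoxy reads as a number 18 percentage points higher from compound 2 to compound 4 (beyond the scatter) and so shows that this place on the oxygen affects growth inhibition. Within this pair, the smaller methyl gives the higher number, so the 4-fluorophenyl is not required for inhibition. No measured evidence accounts for the step. Going by these compounds, whether an unsubstituted phenyl, an ethyl or a longer alkyl chain on this oxygen would read nearer compound 2 or compound 4 stays open. A free hydroxyl at this place is also untested in the compounds shown.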